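Isopropoxy in place of dimethylamino in a three-compound series

The compounds below may be only part of what the source reports. "The series", "measured", "known", "first", "only" and "open" are said of these compounds alone.

Measured so far in an ADME assay on cells (Fibroblast, Homo sapiens) for antiproliferative activity, with a stated time of 48 h (a lower number here means a stronger inhibitor, a higher number a weaker inhibitor), every entry being a limit and not a number:
compound 1 `CCN(CC)c1ccc(-c2ccc(C(C)=O)cc2)nn1`: > 25000 nM
compound 2 `CCOC(=O)c1ccc(-c2ccc(N(C)C)nn2)cc1`: > 25000 nM
compound 3 `COC(=O)c1ccc(-c2ccc(N(C)C)nn2)cc1`: > 25000 nM

In this assay compound 2 stands at > 25000 nM, which is a limit. The other two compounds offer no firmer reference, and the whole set comes down to the limit of > 25000 nM in this assay, at which 3 of the 3 values shown sit. No number is yet available in this series.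

The next structure is compound 4 `CCOC(=O)c1ccc(-c2ccc(OC(C)C)nn2)cc1`. The change is isopropoxy in place of dimethylamino on an aromatic carbon, with isopropoxy in place of dimethylamino on an aromatic carbon, next to the ring nitrogen and para to a large group.

For the measured compounds named here, the only measured step is a step that the two limits leave unreadable from compound 2 to compound 3. It is hydrogen in place of methyl, at a different place from the present change, and it gives no size to carry over. Going by the values given here, no measured step touches the dimethylamino group, so the data point neither to a gain nor to a loss in this assay.

The expected step of a number no higher from compound 2 to compound 4 (the limit leaves the size open) is none beyond the scatter, and another limit is the likeliest report. For compound 4 the estimate is 25000 nM, with an expected range of 10000 nM to 50000 nM.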

Compound 4, half-maximal inhibitory concentration: > 25000 nM
Compound 4: no number, only a limit; the forecaster's own chance of this, stated with the estimate: 70%; the middle value lies on the limit itself.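

In this assay compound 4 gives > 25000 nM, which is a limit and not a number. Compound 2 also stands at a limit, so no step can be read between compound 2 and compound 4. The compounds shown leave open whether any change on the shared core yields a number, as the whole set rests on one entry: the limit of > 25000 nM in this assay, at which 4 of the 4 values shown sit.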